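This account rests on a few compounds, and the source may have more. Where it says the series, first, only, none or still open, it means among the compounds named here.

Compound 1: `Cc1ccccc1Nc1ccc2c(c1)C(=O)N(C1CCC(=O)NC1=O)C2=O` gives 2% in an assay on FRT-Jurkat cells for inhibition of nuclear factor NF-kappa-B complex (Homo sapiens), read by flow cytometry, with a stated time of 24 h, tested at 10 uM; on this read-out lower numbers stand for less inhibition and higher numbers for more inhibition at the one concentration tested (going by the name of the read-out).
Compound 2: `Cc1ccccc1Nc1cccc2c1C(=O)N(C1CCC(=O)NC1=O)C2=O` gives 7% in this assay.
Compound 3: `O=C1CCC(N2C(=O)c3cccc(Nc4ccc(O)cc4)c3C2=O)C(=O)N1` gives 4% in this assay.

All three measured compounds share the same core and differ only in the group attached to the nitrogen on the aromatic ring. Compound 3 stands second highest of the three numbers, with compound 1 nearest and compound 2 furthest, yet every gap among them lies within the scatter, so none can be set apart from the others.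

Compound 4, `CC(=O)c1ccc(Nc2cccc3c2C(=O)N(C2CCC(=O)NC2=O)C3=O)cc1`, is not yet measured. It differs from compound 3 in one place: acetyl in place of hydroxy on an aromatic carbon.

Among the measured compounds shown here, one measured step bears on this change, the swap of the whole aryl group in a number 3 percentage points lower from compound 2 to compound 3 (within the scatter), which stayed within the scatter. That swap altered the same aryl ring without moving the read-out, and nothing in the three compounds shows a group at this place lifting the number. The estimated step of a number 1 percentage points higher from compound 3 to compound 4 (within the scatter) is therefore expected to stay within the scatter. Compound 4 is expected to give 5%, between -5% and 15%.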

Compound 4, a percentage reported as inhibition, at one concentration (the size of the read-out at that concentration, not a potency): 2%
Estimate against measurement, compound 4: 3 percentage points above; the measured number falls inside the stated range.
By their numbers in this assay, from the lowest: compounds 1, 4, 3 and 2 (each within the scatter of the next).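

In this assay, acetyl in place of hydroxy on the aromatic carbon gives a number 2 percentage points lower from compound 3 to compound 4 (within the scatter), so this place accepts a group of three heavy atoms with no hydrogen-bond donor in place of one heavy atom with a donor, and the read-out cannot tell the two compounds apart. The wider swap to 4-acetylphenyl from 2-methylphenyl gives a number 5 percentage points lower from compound 2 to compound 4 (within the scatter), so these two aryl groups cannot be told apart here either. No measurement shown offers an explanation for these results.

Going by these compounds, it remains open whether an amine, a carboxylic acid or a longer chain at this place would give a number beyond the scatter. Each number comes from a single concentration, so none of them gives a potency.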